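A few compounds are considered here, and "the series" means these few. Any claim that something is new, unique, unknown or untested is made for them only; others in the source may bear on it.

In a functional assay for activation of Alpha-1B adrenergic receptor (Homo sapiens), read by calcium flux (a lower number here means that less compound is needed, a higher number that more compound is needed for the effect), compound 1, `c1csc(-c2ccccc2NCC2=NCCN2)c1`, gives 5.75 nM, and compound 3, `c1ccc(-c2cnccn2)c(NCC2=NCCN2)c1`, gives 339 nM. For compound 2, `Cc1nc(-c2ccccc2NCC2=NCCN2)co1`, this assay reports only a limit, < 5020 nM, so compound 2 stands at the limit of < 5020 nM in this assay, at which 1 of the 3 values shown sits, and its step from compound 1 remains unreadable: a step that the limit leaves unreadable from compound 1 to compound 2. For the measured compounds named here, the one readable step is a 59-fold higher number from compound 1 to compound 3 (1.77 log units; beyond the scatter), while a step that the limit leaves unreadable from compound 2 to compound 3 cannot be sized. Compound 4, `c1cnc(-c2ccccc2NCC2=NCCN2)nc1`, differs from compound 2 by pyrimidin-2-yl in place of 2-methyl-1,3-oxazol-4-yl on an aromatic carbon. The change that bears on it is the move to a six-membered ring with two nitrogens, which in the step from compound 1 to compound 3 cost a large amount; compound 4 is therefore expected to land near compound 3, at 500 nM with a range of 100 nM to 3000 nM, a step that the limit leaves unreadable from compound 2 to compound 4.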

Compound 4, half-maximal effective concentration: 77.6 nM
For compound 4 the middle estimate is 6.4-fold (0.81 log units) above the measured one; the whole stated range lies above it.
By their numbers in this assay, from the lowest: compound 1; then compound 4; then compound 3.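

At this place, on an aromatic carbon of a six-membered aromatic ring of carbon only, this assay separates two rings that each carry two nitrogens: pyrimidin-2-yl in place of pyrazin-2-yl gives a 4.4-fold lower number from compound 3 to compound 4 (0.64 log units; beyond the scatter). Against thiophen-2-yl a gap remains, a 13-fold higher number from compound 1 to compound 4 (1.13 log units; beyond the scatter), so pyrimidin-2-yl recovers only part of what pyrazin-2-yl cost. Compound 2 is known only by a limit, and its steps cannot be read: the limit of < 5020 nM in this assay, at which 1 of the 4 values shown sits.

From the compounds shown here alone, it remains open whether pyridin-2-yl, with one ring nitrogen, or furan-2-yl would stand nearer to compound 1 or to compound 4.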